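Fluoro for Trifluoromethyl Carried onto a Second Core

A few compounds are considered here, and "the series" means these few. Any claim that something is new, unique, unknown or untested is made for them only; others in the source may bear on it.

Of the compounds shown here, three have been measured in an assay for inhibition of protein disulfide-isomerase (Homo sapiens), with a stated time of 1 h; on this read-out lower numbers stand for stronger inhibition and higher numbers for weaker inhibition. Compound 1, `Cc1ccnc(NC(c2ccc(C(F)(F)F)cc2)c2ccc3cccnc3c2O)c1`, gives 26500 nM in this assay. Compound 2, `Cc1ccnc(NC(c2ccc(F)cc2)c2ccc3cccnc3c2O)c1`, gives 140 nM. The two share one core and differ in a single place: fluoro in place of trifluoromethyl on an aromatic carbon. That change made the step of a 190-fold lower number from compound 1 to compound 2 (2.28 log units; beyond the scatter).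

Compound 3, `Oc1ccc2[nH]ncc2c1C(c1ccc(C(F)(F)F)cc1)N1CCCCC1`, is built on another core; the difference between the two cores is not broken down here. In this assay compound 3 gives 710 nM, a higher number than compound 2 shows and a lower one than compound 1 shows.

Compound 4, `Oc1ccc2[nH]ncc2c1C(c1ccc(F)cc1)N1CCCCC1`, has not yet been measured. It differs from compound 3 as compound 2 differs from compound 1: fluoro in place of trifluoromethyl on an aromatic carbon. The place is described in the same words for both pairs, on an aromatic carbon of a six-membered aromatic ring of carbon only, para to a large group, so the change is the same one, though the cores that carry it are not.

For the measured compounds named here, the only guide is the step seen on the first core. For compound 4 the expected step is a 10-fold lower number from compound 3 to compound 4 (1.01 log units; beyond the scatter), because the earlier step of a 190-fold lower number from compound 1 to compound 2 (2.28 log units; beyond the scatter) was large. Since the two cores differ, the step on the second core is expected to be smaller and the range kept wide. The estimate for compound 4 in this assay is 70 nM, expected to fall between 10 nM and 400 nM.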

Compound 4, half-maximal inhibitory concentration: 350 nM
Compound 4: middle estimate off by 5.0-fold (0.70 log units), on the low side; low and high end bracket the measured number.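

On the second core, in this assay, fluoro in place of trifluoromethyl on an aromatic carbon gave a 2.0-fold lower number from compound 3 to compound 4 (0.31 log units; beyond the scatter), which runs in the same direction as the step on the first core. The direction of the change therefore held on both cores, but its size did not carry over from one to the other: the same change on two cores in this assay, a 190-fold lower number (2.28 log units; beyond the scatter) from compound 1 to compound 2 and a 2.0-fold lower number (0.31 log units; beyond the scatter) from compound 3 to compound 4, 93-fold (1.97 log units) apart, beyond the scatter of two such steps. For the compounds shown here, this shows that, in this series, the size of the step seen on one core cannot simply be transferred to another, but with only two pairs it does not show which feature of the cores goes with the gap, or why the step is so much larger on the core of compound 1.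

The compounds shown leave open how a chloro, a methoxy or a nitrile, set in the same place on an aromatic carbon of a six-membered aromatic ring of carbon only, would compare with fluoro and trifluoromethyl on either core. They also leave open whether the same change on a third core would give a step closer to the large one or to the modest one, since two cores cannot show how far the size of the step varies across the series.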